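The source may hold more compounds than are shown below. What is called first, only, known or untested is meant among the compounds shown, and "the series" means these compounds.

Among the compounds with values here, compound 2 `Cc1nc(Nc2ccc(Cl)c(Cl)c2)sc1C(=O)/C=C/c1ccccc1` is the one compound here with a number in a functional assay on NCI-H460 cells (Homo sapiens) for cytotoxicity, read by MTT assay (a higher number here means a weaker inhibitor, a lower number a stronger inhibitor), where compound 2 gives 22700 nM. Compound 1 `COc1cccc(/C=C/C(=O)c2sc(Nc3cccc(C)c3)nc2C)c1` reaches only a limit of this assay, giving > 25000 nM. Compound 3 `Cc1cccc(Nc2nc(C)c(C(=O)/C=C/c3ccccc3)s2)c1` has not been measured yet; it differs from compound 2 by 3-methylphenyl in place of 3,4-dichlorophenyl on a nitrogen on an aromatic ring. Within the data shown here, no measured pair isolates this change, and compound 1, which also carries a 3-methylphenyl group, sits at the limit of > 25000 nM in this assay, at which 1 of the 2 values shown sits. The expected step is a 1.4-fold higher number from compound 2 to compound 3 (0.15 log units; within the scatter), a weakening that could reach beyond the usual scatter. Compound 3 is estimated at 32000 nM, within a range from 12000 nM to 90000 nM, with a fair chance that this assay again reports only a limit.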

Compound 3, half-maximal inhibitory concentration: 21800 nM
Compound 3: middle estimate off by 1.5-fold (0.17 log units), on the high side; low and high end bracket the measured number.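

Within the data shown here, on the nitrogen on an aromatic ring, swapping 3,4-dichlorophenyl for 3-methylphenyl gives a 1.0-fold lower number from compound 2 to compound 3 (0.02 log units; within the scatter), the first direct reading of this change in this assay, and the two groups cannot be told apart there. Hydrogen in place of methoxy on an aromatic carbon gives an at least 1.1-fold lower number from compound 1 to compound 3 (0.05 log units; that floor lies within the scatter), which is only a floor and shows no real change. Compound 1 gives only a limit of the assay: the limit of > 25000 nM in this assay, at which 1 of the 3 values shown sits.

On these data alone, it remains open whether any group on that nitrogen moves the number beyond the scatter. A carboxylic acid or an amine on the phenyl ring, or a longer chain in its place, would test this.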